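Furan-2-yl in Place of Bromo: Compound 3 Expected

The source may hold more compounds than are shown below. What is called first, only, known or untested is meant among the compounds shown, and "the series" means these compounds.

Compound 2 `CCCn1c(Br)nc2c(N)nc(NCc3ccccc3)nc21` sits alongside compound 1 `CCCn1c(-c2ccco2)nc2c(N)ncnc21`: in an assay on CHO cells for displacement of a labelled ligand from transmembrane domain-containing protein TMIGD3 (Homo sapiens) (on this read-out lower numbers stand for stronger inhibition and higher numbers for weaker inhibition), compound 2 gives 650 nM, while compound 1 gives 790 nM, and the two lie within the usual scatter of each other. Compound 3 `CCCn1c(-c2ccco2)nc2c(N)nc(NCc3ccccc3)nc21` has not been measured. It differs from compound 2 by furan-2-yl in place of bromo on an aromatic carbon, the same furan-2-yl that compound 1 carries. Among the compounds with values here, no measured pair differs only at this place, so the change is expected to move the number modestly, if at all, toward stronger inhibition a 1.6-fold lower number from compound 2 to compound 3 (0.21 log units; within the scatter). Compound 3 is thus estimated at 400 nM in this assay, within 120 nM to 1300 nM.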

Compound 3, inhibition constant: 29 nM
Estimate against measurement, compound 3: 14-fold (1.14 log units) above; measured number below the stated range.
By their numbers in this assay, from the lowest: compound 3; then compounds 2 and 1 (each within the scatter of the next).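

In this assay, furan-2-yl in place of bromo on this aromatic carbon produces a large gain (a 22-fold lower number from compound 2 to compound 3 (1.35 log units; beyond the scatter)), so the position is far from indifferent when the benzylamino group is present. Benzylamino in place of hydrogen produces a similarly large gain with furan-2-yl already there (a 27-fold lower number from compound 1 to compound 3 (1.44 log units; beyond the scatter)), so each group counts heavily in the presence of the other. No supporting measurement is available to explain these steps. As far as these compounds go, whether a thiophene ring or a phenyl ring would serve on this carbon in place of furan-2-yl stays open, as does whether a simple alkylamine could replace benzylamino.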